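Acetyl for benzyl on the ring nitrogen of compound 2

The source may hold more compounds than are shown below. What is called first, only, known or untested is meant among the compounds shown, and "the series" means these compounds.

Compound 1 `CCCNc1nc(SCc2ccc([N+](=O)[O-])cc2)c2ncn([C@@H]3O[C@H](CO)[C@@H](O)[C@H]3O)c2n1` and compound 2 `O=[N+]([O-])c1ccc(CSc2nc(NCc3ccccc3)nc3c2ncn3[C@@H]2O[C@H](CO)[C@@H](O)[C@H]2O)cc1` share one core and differ only on the chain carbon bound to the ring nitrogen. In an assay on K562 cells for displacement of a labelled ligand from Equilibrative nucleoside transporter 1 (Homo sapiens), read by flow cytometry, with a stated time of 45 min (on this read-out higher numbers stand for weaker inhibition and lower numbers for stronger inhibition), compound 1 gives 193 nM and compound 2 gives 247 nM; the step of a 1.3-fold higher number from compound 1 to compound 2 (0.11 log units; within the scatter) lies within the scatter, so compound 2 holds the higher of the two numbers without this meaning a real difference from compound 1.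

Compound 3 `CC(=O)Nc1nc(SCc2ccc([N+](=O)[O-])cc2)c2ncn([C@@H]3O[C@H](CO)[C@@H](O)[C@H]3O)c2n1` takes the change (acetyl in place of benzyl on a nitrogen on an aromatic ring), acetyl in place of benzyl on a nitrogen on an aromatic ring, benzylamino to acetamido. Within the data shown here, the only measured step, from compound 1 to compound 2, swaps one hydrocarbon group for another and stayed within the scatter; no measured step covers an acetyl on this nitrogen. With the carbonyl group untested in this series, compound 3 is expected to move somewhat toward weaker inhibition, a 2.0-fold higher number from compound 2 to compound 3 (0.31 log units; beyond the scatter), the estimate for compound 3 being 500 nM within 120 nM to 2000 nM.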

Compound 3, inhibition constant: 34 nM
Beside the measured number, compound 3's estimate is 15-fold (1.17 log units) above it; measured number below the stated range.
By their numbers in this assay, from the lowest: compound 3; then compounds 1 and 2 (each within the scatter of the next).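

On the nitrogen on an aromatic ring, the two hydrocarbon groups stay within the scatter of each other, with a 1.3-fold higher number from compound 1 to compound 2 (0.11 log units; within the scatter) in this assay, but acetyl separates clearly from both. Acetyl in place of benzyl gives a 7.3-fold lower number from compound 2 to compound 3 (0.86 log units; beyond the scatter), and acetyl in place of propyl gives a 5.7-fold lower number from compound 1 to compound 3 (0.75 log units; beyond the scatter), so this position does respond to the group it carries, and the lower number holds whichever of the two groups leaves. No measurement on hand accounts for this shift.

Acetyl is the only group here with a carbonyl and a hydrogen-bond acceptor, and it is also the smallest, so these features remain inseparable across the three compounds. A benzoyl or longer acyl group on this nitrogen, or the free amine, would bear on that question.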